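A few compounds are considered here, and "the series" means these few. Any claim that something is new, unique, unknown or untested is made for them only; others in the source may bear on it.

Measured compounds:
compound 1 `COc1ccc(-n2c(=O)n(Cc3cc4cc(Cl)ccc4n3CCCC#N)c3cnccc32)c(F)c1`: > 50000 nM
compound 2 `COc1ccc(-n2c(=O)n(Cc3cc4cc(Cl)ccc4n3CCCC#N)c3cnccc32)cc1OC`: > 50000 nM
compound 3 `N#CCCCn1c(Cn2c(=O)n(-c3ccc(OC(F)(F)F)cc3)c3ccncc32)cc2cc(Cl)ccc21`: > 50000 nM

In an ADME assay on HeLa cells (Homo sapiens) for cytotoxicity, read by ATP content, with a stated time of 3 days (a higher number here means that more compound is tolerated, a lower number that less compound is tolerated), compound 3 gives > 50000 nM, which is a limit of the assay rather than a number. Compound 1 gives > 50000 nM in this assay, also a limit. Compound 2 gives > 50000 nM, again a limit. All three sit at the same limit (the limit of > 50000 nM in this assay, at which 3 of the 3 values shown sit), so compound 3 stands exactly where its two neighbours stand. Compound 4 `N#CCCCn1c(Cn2c(=O)n(-c3ccncc3F)c3ccncc32)cc2cc(Cl)ccc21` differs from compound 3 in one place: 3-fluoropyridin-4-yl in place of 4-(trifluoromethoxy)phenyl on an aromatic nitrogen. Among the compounds with values here, the steps that bear on this change, a step that the two limits leave unreadable from compound 1 to compound 3 and a step that the two limits leave unreadable from compound 2 to compound 3, are both unreadable, since every value is a limit, so no direction can be drawn from them. The estimated step of a number no higher from compound 3 to compound 4 (the limit leaves the size open) is therefore expected to be none beyond the scatter. Compound 4 is expected to give 50000 nM in this assay, between 20000 nM and 100000 nM, most likely again reported as a limit.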

Compound 4, half-maximal cytotoxic concentration: > 50000 nM
Compound 4 ended at the assay's limit (the forecaster's own chance of this, stated with the estimate: 80%); the middle value sits exactly at the limit.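

No step can be read between compound 4 and compound 1, compound 2 or compound 3, because all four values are limits of the assay: the limit of > 50000 nM in this assay, at which 4 of the 4 values shown sit.

The compounds shown leave open whether any of these changes on the aromatic nitrogen shifts the result in this assay, and how the four compounds would rank.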